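The compounds below may be only part of what the source reports. "The series", "measured", "known", "first", "only" and "open" are said of these compounds alone.

Measured compounds in a functional assay on K562 cells (Homo sapiens) for cytotoxicity, read by MTT assay, with a stated time of 24 h; on this read-out higher numbers stand for weaker inhibition and lower numbers for stronger inhibition:

Compound 1, `CC(CC[C@H]1/C(=C/c2ccc(F)cc2)CC[C@H]2C(C)(C)CCC[C@]12C)CC(=O)O`, gives > 200000 nM in this assay, which is a limit of the assay and not a number.
Compound 2, `CC(CC[C@H]1/C(=C/c2ccc(Cl)cc2)CC[C@H]2C(C)(C)CCC[C@]12C)CC(=O)O`, gives > 200000 nM in this assay, again a limit rather than a number.
Compound 3, `CC(CC[C@H]1/C(=C/c2ccc(Br)cc2)CC[C@H]2C(C)(C)CCC[C@]12C)CC(=O)O`, gives > 200000 nM in this assay, once more a limit and not a number.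

Compound 3 therefore stands at the limit of this assay, and it shares that position with the two others (the limit of > 200000 nM in this assay, at which 3 of the 3 values shown sit). The exchanges of one halogen for another among these three, a step that the two limits leave unreadable from compound 1 to compound 2, a step that the two limits leave unreadable from compound 1 to compound 3 and a step that the two limits leave unreadable from compound 2 to compound 3, all remain unreadable, since both ends of each step sit at the limit.

Compound 4, `CC(CC[C@H]1/C(=C/c2ccc(I)cc2)CC[C@H]2C(C)(C)CCC[C@]12C)CC(=O)O`, differs from compound 3 by iodo in place of bromo on an aromatic carbon. This is the same kind of change as the three unreadable steps, and none of them gave a number on either side. No step beyond the scatter is expected here, and the most likely outcome is that compound 4 also sits at the limit, so the step from compound 3 to compound 4 is expected to be a step that the limit leaves unreadable from compound 3 to compound 4. Compound 4 is estimated at 300000 nM, within a range from 100000 nM to 1000000 nM.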

Compound 4, half-maximal inhibitory concentration: 98000 nM
Beside the measured number, compound 4's estimate is 3.1-fold (0.49 log units) above it; measured number below the stated range.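

In this assay, among these compounds, compound 4 gives the first real number of the series, so a change on this aromatic carbon, para to a large group, can bring a reading off the limit. Putting iodo on this carbon gives an at least 2.0-fold lower number from compound 3 to compound 4 (0.30 log units; that floor lies within the scatter), and the same comparison gives an at least 2.0-fold lower number from compound 2 to compound 4 (0.30 log units; that floor lies within the scatter) and an at least 2.0-fold lower number from compound 1 to compound 4 (0.30 log units; that floor lies within the scatter). From the compounds shown here alone, each of these steps is only a floor, with a limit at one end, so its true size remains unknown, the exchanges among compound 1, compound 2 and compound 3 still cannot be read, and most of the series stays at one limit: the limit of > 200000 nM in this assay, at which 3 of the 4 values shown sit.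

The compounds shown leave open how far the number would move with something other than a halogen on this carbon, such as a methoxy group or an amine, or with a methyl ester in place of the carboxylic acid. They also leave open whether iodo on another carbon of the same ring would give a number at all.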